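Meta chloro for trifluoromethyl on a piperazine succinimide

This account rests on a few compounds, and the source may have more. Where it says the series, first, only, none or still open, it means among the compounds named here.

Measured compounds:
- compound 1, `CC(C(=O)N1CCN(c2ccc(Cl)cc2)CC1)N1C(=O)CCC1=O`, 0%
- compound 2, `CC(C(=O)N1CCN(c2ccc(F)cc2)CC1)N1C(=O)CCC1=O`, 0%
- compound 3, `CC(C(=O)N1CCN(c2cccc(C(F)(F)F)c2)CC1)N1C(=O)CCC1=O`, 50%

For the measured compounds named here, in a functional assay on the whole organism (strain Swiss) with Mus musculus as the target, in the maximal electroshock model, with a stated time of 1 h, at a dose of 100 mg/kg by the intraperitoneal route (a higher number here means a stronger effect of the compound at the dose given, a lower number a weaker effect), compound 1 gives 0% and compound 2 gives 0%; the only step between measured neighbours, no change at the digits printed from compound 1 to compound 2 (within the scatter), shows that swapping one halogen for another on the aromatic ring left the read-out unchanged. Compound 3 stands apart: its value of 50% is the highest of the three, lying beyond the scatter above both compound 1 and compound 2.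

Compound 4, `CC(C(=O)N1CCN(c2cccc(Cl)c2)CC1)N1C(=O)CCC1=O`, differs from compound 3 by a single change: chloro in place of trifluoromethyl on an aromatic carbon. Going by the values given here, no measured step shows a chloro replacing a trifluoromethyl, so the halogen-for-halogen step from compound 1 to compound 2 is only a loose guide, and it concerned compounds with no activity at all. Since compound 3 alone carries the trifluoromethyl and alone shows activity, the step of a number 30 percentage points lower from compound 3 to compound 4 (beyond the scatter) is expected to go downward, though with wide uncertainty. Compound 4 is therefore estimated at 20%, within a range from 0% to 50%.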

Compound 4, a percentage reported as activity, at one dose (the size of the read-out at that dose, not a potency): 50%
Compound 4: the middle estimate sits 30 percentage points below what was measured, and the stated range covers the measured number.
By their numbers in this assay, from the lowest: compounds 1 and 2 (each within the scatter of the next); then compounds 3 and 4 (each within the scatter of the next).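

In this assay the swap of trifluoromethyl for chloro gives no change at the digits printed from compound 3 to compound 4 (within the scatter) and so shows that trifluoromethyl is not required on this aromatic carbon for the read-out at this dose. With the chloro group kept, 3-chlorophenyl in place of 4-chlorophenyl gives a number 50 percentage points higher from compound 1 to compound 4 (beyond the scatter) and 3-chlorophenyl in place of 4-fluorophenyl gives a number 50 percentage points higher from compound 2 to compound 4 (beyond the scatter), so across these four compounds the read-out goes with where the group sits on the ring and not with which of these groups it is. No evidence is available on why this should be so.

Going by these compounds, whether a methyl, a methoxy group, an amine or a carboxylic acid on the same aromatic carbon would keep the read-out remains open. Also open, on these data alone, is how compound 3 and compound 4 compare at other doses.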